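Swapping a Nitrile for Isopropyl in a Cytotoxicity Screen

The compounds below may be only part of what the source reports. "The series", "measured", "known", "first", "only" and "open" are said of these compounds alone.

Of the compounds shown here, three sharing one fused core have been measured so far: compound 1 `N#CCCCn1c(Cn2c(=O)n(-c3ccc(C(=O)NC4CC4)cc3)c3ccncc32)cc2cc(Cl)ccc21`, compound 2 `CS(=O)(=O)CCCn1c(Cn2c(=O)n(CC#N)c3ccncc32)cc2cc(Cl)ccc21` and compound 3 `O=c1n(Cc2cc3ncccc3n2CCCCO)c2cnccc2n1C1CC1`, all in an ADME assay on HeLa cells (Homo sapiens) for cytotoxicity, read by ATP content, with a stated time of 3 days; a higher number here means that more compound is tolerated, a lower number that less compound is tolerated. In this assay compound 1 reached only the assay limit of > 50000 nM. In this assay compound 2 likewise gave only the limit of > 50000 nM. In this assay compound 3 gave only the limit of > 100000 nM. Thus no compound yet has a definite number: two values sit at the limit of > 50000 nM in this assay, at which 2 of the 3 values shown sit, and one at the limit of > 100000 nM in this assay, at which 1 of the 3 values shown sits, and compound 2 stands at the former, with no single-change step to any measured neighbour recorded.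

Compound 4 `CC(C)n1c(=O)n(Cc2cc3cc(Cl)ccc3n2CCCS(C)(=O)=O)c2cnccc21` differs from compound 2 in one place: isopropyl in place of cyanomethyl on an aromatic nitrogen. With every measured compound already at a limit, the data give no direction to read from, so the step that the limit leaves unreadable from compound 2 to compound 4 is expected to be none beyond the scatter. For compound 4 in this assay the half-maximal cytotoxic concentration is estimated at 60000 nM, within a range from 20000 nM to 200000 nM, most likely again reported only as a limit.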

Compound 4, half-maximal cytotoxic concentration: > 50000 nM
Compound 4: a limit, no number (the forecaster's own chance of this, stated with the estimate: 75%); the middle value does not contradict the limit.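

No step can be read from compound 2 to compound 4, because both reach only a limit and not a number: the limit of > 50000 nM in this assay, at which 3 of the 4 values shown sit.

The compounds shown leave open at what concentration any of them becomes cytotoxic in this assay, and whether isopropyl and cyanomethyl differ there at all.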